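A Limit-Bound Half-Life and a Cyclohexyl Swap

This account rests on a few compounds, and the source may have more. Where it says the series, first, only, none or still open, it means among the compounds named here.

In a physicochemical assay for pharmacokinetics (on this read-out lower numbers stand for a shorter-lived compound and higher numbers for a longer-lived compound), compound 1 (`COc1cccc(CNC(=O)N2C(=O)c3ccccc3S2(=O)=O)c1`) gives > 166 h, which is a limit and not a number. Compound 2 (`Cc1ccccc1CNC(=O)N1C(=O)c2ccccc2S1(=O)=O`) gives > 166 h, and this too is only a limit. Compound 2 therefore has no exact position on the scale, and the record so far is the limit of > 166 h in this assay, at which 2 of the 2 values shown sit.

Compound 3 (`O=C(NCC1CCCCC1)N1C(=O)c2ccccc2S1(=O)=O`) carries cyclohexyl in place of 2-methylphenyl on a saturated chain carbon bound to an amide-type nitrogen. Within the data shown here, the only measured step that bears on this change is a step that the two limits leave unreadable from compound 1 to compound 2, which offers no size to carry forward. Among the measured compounds shown here, no measured step therefore points to a move in either direction, and none beyond the scatter is expected. The estimated step is a step that the limit leaves unreadable from compound 2 to compound 3. Compound 3 is expected at 200 h, with an estimated range of 110 h to 400 h.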

Compound 3, half-life: > 166 h
Compound 3 gave a limit, no number (the forecaster's own chance of this, stated with the estimate: 70%); the middle value does not contradict the limit.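

Among these compounds, compound 1, compound 2 and compound 3 all give limits and not numbers, so no step between them can be read. The compounds shown leave open how long-lived each one actually is in this assay, and whether swapping these groups changes that at all.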